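Adding a Second Methoxy Group to a Thiosemicarbazone

A few compounds are considered here, and "the series" means these few. Any claim that something is new, unique, unknown or untested is made for them only; others in the source may bear on it.

Measured compounds:
compound 1, `COc1ccc(NC(=S)N/N=C2\C(=O)Nc3ccc([N+](=O)[O-])cc32)cc1`, 15%
compound 2, `N#Cc1cccc(NC(=S)N/N=C2\C(=O)Nc3ccc([N+](=O)[O-])cc32)c1`, 15%

In a functional assay on the whole organism for inhibition, with Lemna aequinoctialis as the target, tested at 100 ug/mL (a lower number here means less inhibition of growth, a higher number more inhibition of growth at the concentration tested), compound 1 gives 15%. Compound 2 gives 15%, and the step of no change at the digits printed from compound 1 to compound 2 (within the scatter) shows that exchanging one aryl group for another on the amide-type nitrogen left the read-out where it was. For the measured compounds named here, compound 1 thus stands level with compound 2 on the numbers at hand, and no measured step from it reaches beyond the scatter.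

Compound 3 `COc1ccc(NC(=S)N/N=C2\C(=O)Nc3ccc([N+](=O)[O-])cc32)c(OC)c1` has not been measured. It differs from compound 1 by a single change: methoxy in place of hydrogen on an aromatic carbon. Going by the values given here, the only measured step bears on this only loosely: it replaced the whole aryl group, a larger alteration than adding one methoxy, and it produced no change beyond the scatter. The shared core is the same in all three compounds. On that footing, the expected step of a number 3 percentage points higher from compound 1 to compound 3 (within the scatter) is none beyond the scatter. Compound 3 is therefore estimated to give 18% in this assay, with a range from 5% to 35%, the estimate resting only on the flat step observed so far.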

Compound 3, percent growth inhibition at one concentration: 25%
Estimate against measurement, compound 3: 7 percentage points below; the measured number falls inside the stated range.
By their numbers in this assay, from the lowest: compounds 1, 2 and 3 (each within the scatter of the next).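

Compound 3 carries a methoxy on an aromatic carbon ortho to a large group and meta to a methoxy group, and in this assay the change gives a number 10 percentage points higher from compound 1 to compound 3 (within the scatter), so this single addition does not move the read-out beyond what repeated measurements would be expected to show. The earlier comparison exchanged one whole aryl group for another, whereas this one alters a single place on the ring and leaves everything else untouched, so the flat picture now extends to a small, local change as well as to a large one. Nothing measured alongside these growth-inhibition numbers offers an explanation of why the read-out responds in this way.

Open questions remain about how far this tolerance extends, since a single methoxy says little about whether an amine, a carboxylic acid or a longer chain such as butoxy at the same place would shift the read-out beyond the scatter. It is also unknown whether the same methoxy would behave alike on the nitrile-bearing ring of compound 2, where the surrounding groups differ.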